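This account rests on a few compounds, and the source may have more. Where it says the series, first, only, none or still open, it means among the compounds named here.

Working notes on the series in an ADME assay on THP-1 cells (Homo sapiens) for inhibition, read by MTT assay, with a stated time of 72 h; a higher number here means a weaker inhibitor of growth, a lower number a stronger inhibitor of growth. Compound 1 `Cc1ccc2oc(-c3cc4ccccc4s3)cc(=O)c2c1` is reported only as a limit: in this assay compound 1 gives > 100 ug/mL. Compound 3 `Cc1cc2oc(-c3cc4ccccc4s3)cc(=O)c2cc1Cl` is likewise a limit, giving > 100 ug/mL in this assay. Compound 2 `Cc1ccc(C(=O)CC(=O)c2cc3ccccc3s2)c(O)c1` is the parent of the step followed here; in this assay compound 2 also returns a limit, > 100 ug/mL. Where compound 2 stands is thus known only as a limit, and the same holds for every value so far: the limit of > 100 ug/mL in this assay, at which 3 of the 3 values shown sit. Among the compounds with values here, no step between measured compounds can be sized from these data.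

Compound 4 `O=C(CC(=O)c1ccccc1O)c1cc2ccccc2s1` has not yet been measured in this assay. It differs from compound 2 in one place: hydrogen in place of methyl on an aromatic carbon.

With every measured value sitting at the limit, no direction for this step can be read off; it is expected to stay within the usual scatter, and the step is estimated at a step that the limit leaves unreadable from compound 2 to compound 4. Compound 4 is expected to give about 150 ug/mL in this assay, within a range from 60 ug/mL to 400 ug/mL, with a limit rather than a number the likelier report.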

Compound 4, concentration for 50% growth inhibition: > 100 ug/mL
Compound 4: only a limit was reported (the forecaster's own chance of this, stated with the estimate: 80%); the middle value does not contradict the limit.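

Compound 2 and compound 4 are both reported only as limits in this assay, and the step between them, hydrogen in place of methyl on an aromatic carbon, cannot be read. The compounds shown leave open whether any change to the shared core gives a measurable inhibition of growth: the limit of > 100 ug/mL in this assay, at which 4 of the 4 values shown sit.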